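The compounds below may be only part of what the source reports. "The series", "measured", "known", "first", "only" and "open" are said of these compounds alone.

Measured so far:
- compound 1 `Cc1ccc(-c2nc(SC[C@H]3C[C@@](C)(O)CC(=O)O3)[nH]c2-c2ccc(C)cc2)cc1.Cc1ccc(-c2nc(SC[C@H]3C[C@](C)(O)CC(=O)O3)[nH]c2-c2ccc(C)cc2)cc1`: 170 nM
- compound 2 `CC1=CC(=O)OC(CSc2nc(-c3ccccc3)c(-c3ccccc3)[nH]2)C1`: 200 nM

In an assay on microsomes from liver for inhibition of sterol O-acyltransferase 1 (Rattus norvegicus) (on this read-out lower numbers stand for stronger inhibition and higher numbers for weaker inhibition), compound 1 gives 170 nM, and compound 2 gives 200 nM. Compound 2 has the higher of these two numbers, but its gap to compound 1 lies within the scatter, so the two cannot be told apart on this read-out.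

Compound 3 `c1ccc(-c2nc(SCC3CCCCC3)[nH]c2-c2ccccc2)cc1` has not yet been measured. It differs from compound 2 in one place: a group of 6 heavy atoms (6 carbon; one six-membered non-aromatic ring of carbon only) in place of a group of 8 heavy atoms (6 carbon, 2 oxygen; one six-membered non-aromatic ring with 1 hetero atom), on a saturated chain carbon bound to a sulfur. The group of 8 heavy atoms with its two oxygen atoms and two double bonds outside aromatic rings gives way to cyclohexyl, a ring of carbon only with no hydrogen-bond donors or acceptors.

Among the measured compounds shown here, no step between measured compounds shows what such a change does here. The expectation is a modest loss of potency, a step of a 2.0-fold higher number from compound 2 to compound 3 (0.30 log units; within the scatter), though the scatter leaves room for no change at all. Compound 3 is therefore estimated at 400 nM, with a range from 100 nM to 1600 nM.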

Compound 3, half-maximal inhibitory concentration: 100 nM
Beside the measured number, compound 3's estimate is 4.0-fold (0.60 log units) above it; measured number inside the range.
By their numbers in this assay, from the lowest: compounds 3, 1 and 2 (each within the scatter of the next).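

In this assay, replacing the group of 8 heavy atoms with cyclohexyl on the saturated chain carbon bound to a sulfur gives a 2.0-fold lower number from compound 2 to compound 3 (0.30 log units; within the scatter) and so leaves the two compounds indistinguishable. For this one pair, then, a number in this range does not require the ring oxygen, the carbonyl or the double bonds of the departing group, since cyclohexyl is a ring of carbon only with no hydrogen-bond donors or acceptors. Nothing shown explains why the two groups read alike.

Going by these compounds, it remains open whether a longer chain, an amine or a carboxylic acid at this place would also keep the number in this range. A single pair also cannot show whether the same exchange would read alike on a different core.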